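A 4-aminophenyl swap on compound 2

The source may hold more compounds than are shown below. What is called first, only, known or untested is meant among the compounds shown, and "the series" means these compounds.

Measured in a functional assay on MCF7 cells (Homo sapiens) for antiproliferative activity, read by MTT assay, with a stated time of 48 h; a lower number here means a stronger inhibitor, a higher number a weaker inhibitor:
- compound 1 `O=c1cc(-n2cc(CSc3ccccc3)nn2)c2cc(Br)ccc2o1`: 36800 nM
- compound 2 `O=c1cc(-n2cc(COc3ccccc3Br)nn2)c2cc(Br)ccc2o1`: 28900 nM

Among the compounds with values here, compound 2, at 28900 nM, stands within the scatter of its only measured neighbour, compound 1. Compound 3 `Nc1ccc(OCc2cn(-c3cc(=O)oc4ccc(Br)cc34)nn2)cc1` carries 4-aminophenyl in place of 2-bromophenyl on an oxygen on a saturated carbon. Within the data shown here, the only measured step near this place is a 1.3-fold lower number from compound 1 to compound 2 (0.10 log units; within the scatter), and it introduced 2-bromophenoxy in place of phenylsulfanyl. Among the measured compounds shown here, no measured compound carries 4-aminophenyl, so that small step is weak guidance. In this assay the expected step is a 1.2-fold lower number from compound 2 to compound 3 (0.06 log units; within the scatter), so none beyond the scatter is anticipated. Compound 3 is estimated at 25000 nM, with an expected range of 9000 nM to 60000 nM.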

Compound 3, half-maximal inhibitory concentration: 2040 nM
The estimate for compound 3 lay 12-fold (1.09 log units) above the measured number, outside the stated range (below it).
By their numbers in this assay, from the lowest: compound 3; then compounds 2 and 1 (each within the scatter of the next).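

In this assay, within the data shown here, the group on an oxygen on a saturated carbon matters far more than the earlier compounds suggested: 4-aminophenyl in place of 2-bromophenyl gives a clear gain (a 14-fold lower number from compound 2 to compound 3 (1.15 log units; beyond the scatter)), although the step between compounds 1 and 2 stayed within the scatter. 4-Aminophenoxy in place of phenylsulfanyl likewise gives a large change (an 18-fold lower number from compound 1 to compound 3 (1.26 log units; beyond the scatter)). Nothing available explains these gains. The compounds shown leave open whether the amine or its ring position drives the change, as both differ from compound 2 at once. A 4-bromophenyl or 2-aminophenyl group on that oxygen would separate the two.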